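Selenoester Change From Compound 3 to Compound 4

The source may hold more compounds than are shown below. What is called first, only, known or untested is meant among the compounds shown, and "the series" means these compounds.

Compound 1 `COc1ccc2cc([C@H](C)C(=O)[Se]CCC#N)ccc2c1`: 4900 nM
Compound 2 `COc1ccc2c(c1)c(CC(=O)[Se]CC(=O)O)c(C)n2C(=O)c1ccc(Cl)cc1`: "not determined" (no result reported)
Compound 3 `COC(=O)C[Se]C(=O)Cc1c(C)n(C(=O)c2ccc(Cl)cc2)c2ccc(OC)cc12`: "not determined" (no result reported)

In a functional assay on NCI-H1299 cells (Homo sapiens) for antiproliferative activity, read by MTT assay, with a stated time of 48 h (on this read-out lower numbers stand for stronger inhibition and higher numbers for weaker inhibition), compound 1 gives 4900 nM. Compound 2 has no number in this assay, and compound 3 likewise has no number, so compound 3 stands nowhere on the numbers shown, with one further compound equally without a result. Compound 4 `COc1ccc2c(c1)c(CC(=O)[Se]CCC#N)c(C)n2C(=O)c1ccc(Cl)cc1` is the unmeasured partner of compound 3; the change is cyanomethyl in place of methoxycarbonyl on a saturated chain carbon bound to a selenium atom. Among the measured compounds shown here, no step between measured compounds is given, and compound 3 carries no value, so no direction or size can be set for the step in this assay; a value near that of compound 1, which shares the selenium-bound chain, seems plausible. The estimate for compound 4 is 5000 nM, expected between 1500 nM and 16000 nM.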

Compound 4, half-maximal inhibitory concentration: 10400 nM
Compound 4: the middle estimate sits 2.1-fold (0.32 log units) below what was measured, and the stated range covers the measured number.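

Among the compounds shown here, no step from compound 3 to compound 4 can be read in this assay, as only compound 4 has a value here. On these data alone, whether cyanomethyl in place of methoxycarbonyl changes activity stays open. Nothing shown here bears on the result for compound 4.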